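The source may report more compounds than this note shows. Statements on the series, on what has been measured and on what is new or still open speak of the compounds shown alone.

Measured compounds:
compound 1, `Nc1nc(-c2ccccc2)cn2cc(-c3ccccc3)nc12`, 23%
compound 2, `COc1cccc(-c2cn3cc(-c4ccccc4)nc3c(N)n2)c1`, 21%
compound 3, `COc1ccc(-c2cn3cc(-c4ccccc4)nc3c(N)n2)cc1`, 23%

All three were tested in an assay on cells for displacement of a labelled ligand from transmembrane domain-containing protein TMIGD3 (Homo sapiens), read by scintillation counting, with a stated time of 120 min, tested at 1 uM; on this read-out higher numbers stand for more inhibition at the one concentration tested (going by the name of the read-out) and lower numbers for less inhibition. Compound 3 stands level with compound 1, and the two together give the highest numbers of the three, while compound 2 sits a number 2 percentage points higher from compound 2 to compound 3 (within the scatter) away, which is within the scatter. Compound 4, `Nc1nc(-c2ccc(Cl)cc2)cn2cc(-c3ccccc3)nc12`, is not yet measured; it differs from compound 3 in one place: chloro in place of methoxy on an aromatic carbon. Among the measured compounds shown here, no measured step swaps in a chloro, so only the methoxy steps bear on it indirectly: no change at the digits printed from compound 1 to compound 3 (within the scatter) and a number 2 percentage points lower from compound 1 to compound 2 (within the scatter), both within the scatter. Changes at this aromatic carbon have so far left the read-out flat, so compound 4 is expected to stay near compound 3, with an estimated step of a number 1 percentage points higher from compound 3 to compound 4 (within the scatter). The estimate for compound 4 is 24%, expected between 10% and 40%.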

Compound 4, a percentage reported as inhibition, at one concentration (the size of the read-out at that concentration, not a potency): 1%
Compound 4: middle estimate off by 23 percentage points, on the high side, and the stated range ends above it.
By their numbers in this assay, from the lowest: compound 4; then compounds 2, 1 and 3 (each within the scatter of the next).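

In this assay this aromatic carbon turns out to be sensitive to what sits on it: chloro in place of methoxy gives a number 22 percentage points lower from compound 3 to compound 4 (beyond the scatter), chloro in place of hydrogen gives a number 22 percentage points lower from compound 1 to compound 4 (beyond the scatter), and 4-chlorophenyl in place of 3-methoxyphenyl gives a number 20 percentage points lower from compound 2 to compound 4 (beyond the scatter). Of the groups shown, only chloro moves the number beyond the scatter, whereas hydrogen and methoxy sit level. No available data explain this lowering.

On these data alone, it remains open whether fluoro, bromo or methyl on this carbon would lower the number as chloro does. An amine there could equally well behave like methoxy or like chloro.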